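Adding an Isopropyl Group to a Simple Enone Acid

This account rests on a few compounds, and the source may have more. Where it says the series, first, only, none or still open, it means among the compounds named here.

Measured compounds:
- Compound 1, `O=C(O)/C=C/C(=O)c1ccccc1`: 30600 nM
- Compound 2, `CC(C)c1ccc(C(C)C)c(C(=O)/C=C/C(=O)O)c1`: 4750 nM
- Compound 3, `O=C(O)/C=C/C(=O)C1CCc2ccccc2C1`: 7010 nM

All three compounds were tested in a functional assay on HeLa cells (Homo sapiens) for inhibition, read by MTT assay, with a stated time of 72 h; a higher number here means a weaker inhibitor, a lower number a stronger inhibitor. Among them, compound 1 has the highest number, so it is the weakest inhibitor of the three: compound 3 gives a number that is lower by a margin beyond the scatter, and compound 2 gives a number lower still. Both of the stronger inhibitors carry more carbon around the core of compound 1 than compound 1 does, although neither differs from compound 1 in only one place, so no single clean step can be read from them.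

The unmeasured compound 4, `CC(C)c1ccc(C(=O)/C=C/C(=O)O)cc1`, differs from compound 1 in exactly one place: isopropyl in place of hydrogen on an aromatic carbon. The change adds three carbon atoms and nothing else, no ring and no polar group.

Since compound 2, which carries two isopropyl groups, gives 4750 nM against 30600 nM for compound 1, a single isopropyl is expected to move the number in the same direction, by less than compound 2 does but beyond the scatter. The expected step is a 2.6-fold lower number from compound 1 to compound 4 (0.41 log units; beyond the scatter).

Compound 4 is therefore estimated at 12000 nM, with a range from 5000 nM to 30000 nM.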

Compound 4, half-maximal inhibitory concentration: 4900 nM
For compound 4 the middle estimate is 2.4-fold (0.39 log units) above the measured one; the measured number lies below the stated range.
By their numbers in this assay, from the lowest: compounds 2, 4 and 3 (each within the scatter of the next); then compound 1.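

Going by these compounds alone, replacing hydrogen with isopropyl on an aromatic carbon, para to a group of 7 heavy atoms, gives a 6.2-fold lower number from compound 1 to compound 4 (0.80 log units; beyond the scatter) in this assay and provides the first step in this set that can be traced to one change. The earlier compounds shown here differed from compound 1 in more than one place, whereas this result shows that isopropyl at this position alone is enough to give a stronger inhibitor, with a step beyond the usual scatter. The change adds three carbon atoms and no ring, hydrogen-bond donor or hydrogen-bond acceptor, but nothing shown here gives a measured reason for the step.

The compounds shown do not tell whether this step belongs to isopropyl itself or would also appear with a methyl group, a tert-butyl group or a longer chain, or with a hydroxyl group or an amine carrying different atoms at the same position. They also leave open whether a single isopropyl on another carbon of the aromatic ring would give a step of similar size.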